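One group exchanged: from compound 2 to compound 4

The compounds below may be only part of what the source reports. "The series", "measured", "known", "first", "only" and "open" are said of these compounds alone.

In a physicochemical assay for solubility, in simulated intestinal fluid, measured as thermodynamic solubility, at pH 6.8 (on this read-out higher numbers stand for higher solubility and lower numbers for lower solubility), compound 1 `CC(C)(C)OC(=O)N1CCCC(Nc2nc3c(c(Nc4ccc(C(F)(F)F)cc4)n2)CCN(c2ncccc2C(F)(F)F)CC3)C1` gives 14 ug/mL and compound 2 `CN(c1nc2c(c(Nc3ccc(C(F)(F)F)cc3)n1)CCN(c1ncccc1C(F)(F)F)CC2)C1CCCNC1` gives 211 ug/mL with compound 3 `CN1CCCCC1CNc1nc2c(c(Nc3ccc(C(F)(F)F)cc3)n1)CCN(c1ncccc1C(F)(F)F)CC2` at 254 ug/mL alongside them. Compound 2 thus shows a far higher number than compound 1 and stands level with compound 3 within the scatter. The change to compound 4 `CNC1CCN(c2nc3c(c(Nc4ccc(C(F)(F)F)cc4)n2)CCN(c2ncccc2C(F)(F)F)CC3)C1` is 3-(methylamino)pyrrolidin-1-yl in place of methyl(piperidin-3-yl)amino on an aromatic carbon so a six-membered non-aromatic ring gives way to a five-membered one. Among the compounds with values here, the one measured swap at that carbon gave a 1.2-fold higher number from compound 2 to compound 3 (0.08 log units; within the scatter) and thus lay within the scatter. Within the data shown here, with only that guide, the step expected in this assay is a 1.1-fold lower number from compound 2 to compound 4 (0.02 log units; within the scatter) and none beyond the scatter is foreseen. The estimate for compound 4 is 200 ug/mL and the range expected runs from 90 ug/mL to 420 ug/mL as a rough guide.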

Compound 4, solubility: 233 ug/mL
Estimate against measurement, compound 4: 1.2-fold (0.07 log units) below; the range from low to high includes it.
By their numbers in this assay, from the lowest: compound 1; then compounds 2, 4 and 3 (each within the scatter of the next).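

With 3-(methylamino)pyrrolidin-1-yl on this aromatic carbon, this assay gives a 1.1-fold higher number from compound 2 to compound 4 (0.04 log units; within the scatter) and a 1.1-fold lower number from compound 3 to compound 4 (0.04 log units; within the scatter). This position has now taken three different amine-bearing groups with no step beyond the scatter among compounds 2, 3 and 4, and here that includes a five-membered non-aromatic ring giving way from a six-membered one. No available measurement offers an explanation for this. Still open, from the compounds shown here alone, is how this assay would read with a carboxylic acid or an open-chain amine on this carbon.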